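A few compounds are considered here, and "the series" means these few. Any claim that something is new, unique, unknown or untested is made for them only; others in the source may bear on it.

Measured compounds:
Compound 1 `C(=N/Nc1nc2ccccc2nc1Cc1ccccc1)\c1ccccc1` — 320000 nM
Compound 2 `C/C(=N\Nc1nc2ccccc2nc1Cc1ccccc1)c1ccccc1` — 980000 nM
Compound 3 `C/C(=N\Nc1nc2ccccc2nc1Cc1ccccc1)c1cccs1` — 850000 nM

All three were tested in an assay on isolated protein for inhibition of Amine oxidase [flavin-containing] B (Homo sapiens), read by spectrophotometry; on this read-out lower numbers stand for stronger inhibition and higher numbers for weaker inhibition. Compound 3 gives 850000 nM in this assay, the second highest of the three numbers. Its nearest neighbour is compound 2, with a 1.2-fold lower number from compound 2 to compound 3 (0.06 log units; within the scatter), a gap within the scatter, so the two are not distinguished. The furthest is compound 1, at 320000 nM, with a 2.7-fold higher number from compound 1 to compound 3 (0.42 log units; beyond the scatter).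

Compound 4 `C=NNc1nc2ccccc2nc1Cc1ccccc1` is the next compound and has not yet been measured. It differs from compound 3 in one place: a group of 2 heavy atoms (1 carbon, 1 nitrogen; no ring) in place of a group of 8 heavy atoms (6 carbon, 1 nitrogen, 1 sulfur; one five-membered aromatic ring with 1 hetero atom), on a nitrogen on an aromatic ring.

Going by the values given here, two measured steps bear on this change, since both alter the group on the same nitrogen. Going from compound 1 gave a 3.1-fold higher number from compound 1 to compound 2 (0.49 log units; beyond the scatter) and a 2.7-fold higher number from compound 1 to compound 3 (0.42 log units; beyond the scatter), both modest rises beyond the scatter. Among the compounds with values here, no measured step removes the aromatic ring from this group altogether, so the size of the change is not directly covered. On the available numbers a step of no more than modest size, if any, is expected in this assay, most likely towards a higher number. Compound 4 is therefore estimated at 1500000 nM, with a range from 500000 nM to 5000000 nM, which corresponds to an expected step of a 1.8-fold higher number from compound 3 to compound 4 (0.25 log units; within the scatter).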

Compound 4, half-maximal inhibitory concentration: 950000 nM
For compound 4 the middle estimate is 1.6-fold (0.20 log units) above the measured one; the range from low to high includes it.
By their numbers in this assay, from the lowest: compound 1; then compounds 3, 4 and 2 (each within the scatter of the next).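

In this assay, the group of 2 heavy atoms with no ring, on a nitrogen on an aromatic ring, cannot be told apart from the larger ring-bearing groups of the neighbouring compounds: the change gives a 1.1-fold higher number from compound 3 to compound 4 (0.05 log units; within the scatter) and also a 1.0-fold lower number from compound 2 to compound 4 (0.01 log units; within the scatter) in this series. Losing the ring altogether thus leaves the number level with those of the thiophen-2-yl and phenyl compounds, so among these compounds an aromatic ring in this group is not required for that level, and only compound 1 stands apart, with a 3.0-fold higher number from compound 1 to compound 4 (0.47 log units; beyond the scatter) as a modest step. No measurement shown here accounts for this result.

From the compounds shown here alone, whether a phenyl ring carrying a chlorine or a methoxy group, a longer alkyl chain, or an amine in this place would move the number away from that level remains open. All four compounds share the same core, so they also say nothing about how a change elsewhere in it would read.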